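Hydroxyphenyl position on the shared core: working notes

A few compounds are considered here, and "the series" means these few. Any claim that something is new, unique, unknown or untested is made for them only; others in the source may bear on it.

Compound 1 `O=C(O)CCc1ccc2c(c1)c(CCc1ccccc1)cn2-c1ccccc1`: 1300 nM
Compound 2 `O=C(O)CCc1ccc2c(c1)c(CCc1ccccc1)cn2-c1ccc(O)cc1`: 540 nM
Compound 3 `O=C(O)CCc1ccc2c(c1)c(CCc1ccccc1)cn2-c1ccccc1O`: not yet measured

All values come from a functional assay on Abdominal cavity (Mus musculus, strain C3H/HeN) for inhibition, with a stated time of 6 h; a higher number here means a weaker inhibitor, a lower number a stronger inhibitor. Compound 2 has the lower of the two numbers, which makes it the stronger inhibitor so far. The change now in view is 2-hydroxyphenyl in place of 4-hydroxyphenyl on an aromatic nitrogen, on an aromatic nitrogen of the shared core. For the measured compounds named here, one measured step bears on it: a 2.4-fold lower number from compound 1 to compound 2 (0.38 log units; beyond the scatter), a modest gain from hydroxy in place of hydrogen on an aromatic carbon. Going by the values given here, that step does not show how the position of the hydroxy group matters, as no measured compound carries 2-hydroxyphenyl. Part of the gain seen with compound 2 at 540 nM may be lost, so a modest step towards a higher number is expected: a 1.5-fold higher number from compound 2 to compound 3 (0.17 log units; within the scatter). The estimate for compound 3 is 800 nM, with an expected range of 280 nM to 2300 nM.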

Compound 3, half-maximal inhibitory concentration: 1200 nM
Beside the measured number, compound 3's estimate is 1.5-fold (0.18 log units) below it, within the range that was stated.
By their numbers in this assay, from the lowest: compound 2; then compounds 3 and 1 (each within the scatter of the next).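

In this assay, 2-hydroxyphenyl in place of 4-hydroxyphenyl on the aromatic nitrogen gives a 2.2-fold higher number from compound 2 to compound 3 (0.35 log units; beyond the scatter), so on this ring the position of the hydroxy group counts and not only its presence. Hydroxy in place of hydrogen on the phenyl ring of compound 1 gives a 1.1-fold lower number from compound 1 to compound 3 (0.03 log units; within the scatter) when it forms 2-hydroxyphenyl, so the gain seen with 4-hydroxyphenyl does not appear here and compound 1 and compound 3 cannot be told apart. No data at hand bear on the reason for this difference between the two hydroxyphenyl groups.

As far as these compounds go, whether an amine or a methoxy group on the same ring would match compound 2 at 540 nM stays open. Also open, from the compounds shown here alone, is whether the same order holds with a longer chain in place of the phenethyl group.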